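Cytotoxicity notes on the shared-core series, outlook for compound 3

This account rests on a few compounds, and the source may have more. Where it says the series, first, only, none or still open, it means among the compounds named here.

Measured so far:
- compound 1 `COc1ccc(CSc2nc(Cc3cccc(Br)c3)c(C)c(=O)[nH]2)cc1`; in an ADME assay on MT4 cells (Homo sapiens) for cytotoxicity, read by MTT assay (on this read-out higher numbers stand for lower toxicity in this test and lower numbers for higher toxicity in this test), compound 1 gives > 290000 nM, which is a limit of the assay.
- compound 2 `COc1ccc(CSc2nc(Cc3ccc(Br)cc3)c(C)c(=O)[nH]2)cc1`; in this assay compound 2 gives > 290000 nM, again a limit of the assay and not a number.

Compound 2 therefore stands at the upper limit of this assay, with no exact number known for it. Within the data shown here, the single measured step, a step that the two limits leave unreadable from compound 1 to compound 2, cannot be read because of the limit of > 290000 nM in this assay, at which 2 of the 2 values shown sit; it tells neither size nor direction.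

Compound 3 `COc1ccc(CSc2nc(Cc3cc(C)cc(C)c3)c(C)c(=O)[nH]2)cc1` differs from compound 2 by 3,5-dimethylphenyl in place of 4-bromophenyl on a saturated chain carbon bound to an aromatic carbon. Among the measured compounds shown here, no measured step bears on this change: the only step available is the unreadable one from compound 1 to compound 2, and both of its ends are limits. On the numbers shown there is no sign of any compound leaving the limit, so compound 3 is expected to behave like compound 2, and the expected step that the limit leaves unreadable from compound 2 to compound 3 is none beyond the scatter. Compound 3 is accordingly estimated at 300000 nM, with an expected range from 150000 nM to 600000 nM, most likely reported again only as a limit.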

Compound 3, half-maximal cytotoxic concentration: > 329000 nM
Compound 3: a limit, no number (the forecaster's own chance of this, stated with the estimate: 85%); at least 1.0-fold (0.04 log units) between middle value and limit.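

In this assay compound 3 gives > 329000 nM, which is a limit of the assay and not a number. The steps from compound 1 and compound 2 to compound 3 therefore cannot be read, in size or direction. The compounds shown leave open whether 3-bromophenyl, 4-bromophenyl and 3,5-dimethylphenyl differ at all in this assay, since none gives an exact value.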